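Swapping 4-methylphenyl for pyridin-2-yl: a drop is expected

A few compounds are considered here, and "the series" means these few. Any claim that something is new, unique, unknown or untested is made for them only; others in the source may bear on it.

Among the compounds with values here, compound 1 `Cc1ccc(-c2ccccc2OC(C)C2=NCCN2)cc1` is the only member of this set with a number rather than a limit: in a functional assay on CHO cells for agonist activity at Alpha-2C adrenergic receptor (Homo sapiens) (on this read-out higher numbers stand for larger maximal responses and lower numbers for smaller maximal responses), compound 1 gives 0.46. Compound 2 `CC(Oc1ccccc1-c1ccncc1)C1=NCCN1` sits at a limit of the assay, < 0.3. Compound 3 `CC(Oc1ccccc1-c1ccccc1O)C1=NCCN1` likewise sits at a limit, < 0.3. Both steps away from compound 1 lie beyond the scatter: a number at least 0.16 lower from compound 1 to compound 2 (beyond the scatter) and a number at least 0.16 lower from compound 1 to compound 3 (beyond the scatter). The step between compound 2 and compound 3 is a step that the two limits leave unreadable from compound 2 to compound 3. Compound 4 `CC(Oc1ccccc1-c1ccccn1)C1=NCCN1` differs from compound 1 by pyridin-2-yl in place of 4-methylphenyl on an aromatic carbon. Because compound 2, which carries pyridin-4-yl at the same place, reaches only (the limit of < 0.3 in this assay, at which 2 of the 3 values shown sit), a drop of comparable size is expected for compound 4. For compound 4 the expected step is a number 0.21 lower from compound 1 to compound 4 (beyond the scatter). The estimate for compound 4 is 0.25, between 0.1 and 0.42.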

Compound 4, intrinsic activity: the largest response reached, as a fraction of the reference agonist's: < 0.3
Compound 4 gave a limit, no number (the forecaster's own chance of this, stated with the estimate: 60%); the middle value is on the limit's open side.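

In this assay, pyridin-2-yl in place of 4-methylphenyl gives a number at least 0.16 lower from compound 1 to compound 4 (beyond the scatter). Compound 4 ends at a limit of the assay rather than a number, so a second pyridine placement also fails to return a readable value: the limit of < 0.3 in this assay, at which 3 of the 4 values shown sit. The steps among compound 2, compound 3 and compound 4 cannot be read, so these three cannot be ranked.

As far as these compounds go, it remains open how much of the response of compound 1 depends on its methyl group. Plain phenyl, 4-chlorophenyl or 4-methoxyphenyl at this place could begin to answer that.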